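The source may hold more compounds than are shown below. What is called first, only, known or untested is meant among the compounds shown, and "the series" means these compounds.

Measured in a functional assay (trachea) with Cavia porcellus as the target; a higher number here means that more compound is needed for the effect, a lower number that less compound is needed:
- compound 1 `CCCCCCCc1ccc(C/C=C/[C@H](SCC(NC(=O)CCC(N)C(=O)O)C(=O)NCC(=O)O)[C@H](O)CCCC(=O)O)cc1`: 574 nM
- compound 2 `CCCCCCCc1ccccc1C/C=C/[C@H](SCC(NC(=O)CCC(N)C(=O)O)C(=O)NCC(=O)O)[C@H](O)CCCC(=O)O`: 18600 nM

Compound 1, at 574 nM, has the lower of the two numbers in this assay, so less of it is needed for the effect. The gap to compound 2, at 18600 nM, lies beyond the scatter. Among the compounds with values here, with only two measured compounds, no trend can be drawn from this.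

The next compound to be tested is compound 3 `CCCCC/C=C/c1ccc(C/C=C/[C@H](SCC(NC(=O)CCC(N)C(=O)O)C(=O)NCC(=O)O)[C@H](O)CCCC(=O)O)cc1`. It keeps the core of compound 1 and carries hept-1-en-1-yl in place of heptyl on an aromatic carbon, para to a large group: hept-1-en-1-yl in place of heptyl on an aromatic carbon. Within the data shown here, no measured pair isolates this exchange, and the series offers no direct precedent for it.

The expectation in this assay is a small step, none beyond the scatter, with a slight lean towards a lower number. In numbers, the expected change is a 1.3-fold lower number from compound 1 to compound 3 (0.11 log units; within the scatter). The range stays wide, as compound 2 at 18600 nM shows how far the number can move within this series. For compound 3 the estimated value is 450 nM, with an expected range of 120 nM to 1700 nM.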

Compound 3, half-maximal effective concentration: 3820 nM
The estimate for compound 3 lay 8.5-fold (0.93 log units) below the measured number; measured number outside the range, above it.
By their numbers in this assay, from the lowest: compound 1; then compound 3; then compound 2.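

In this assay, within the data shown here, hept-1-en-1-yl in place of heptyl on an aromatic carbon, para to a large group, gives a 6.7-fold higher number from compound 1 to compound 3 (0.82 log units; beyond the scatter), the first reading of a single exchange at this position. Both groups have 7 heavy atoms and no ring, and the only counted difference is the 1 double bond outside aromatic rings, so the number at this position can move beyond the scatter with the carbon count unchanged. No measurement here gives a reason for the size or direction of this step.

A single exchange does not separate the presence of the double bond from its placement at the ring end of the chain or from its geometry, and a hept-2-en-1-yl chain or a hept-1-yn-1-yl chain on the same aromatic carbon would bear on that. The compounds shown also leave open how the number follows chain length at this position, from a shorter pentyl chain to a longer nonyl chain, and whether an ether oxygen within the chain is tolerated.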